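The source may hold more compounds than are shown below. What is called first, only, known or untested is meant among the compounds shown, and "the series" means these compounds.

Of the compounds shown here, three from this series have been tested so far. Compound 1 `COc1cccc([C@H](O)[C@H]2CO[C@H](c3ccc(OC)c(OC)c3)[C@@H](C/C=C/c3ccc(OC)c(OC)c3)C2)c1` gives 21200 nM in a functional assay on HeLa cells (Homo sapiens) for cytotoxicity, read by WST assay, with a stated time of 48 h (a lower number here means a stronger inhibitor, a higher number a weaker inhibitor), compound 2 `COc1ccc([C@H](O)[C@H]2CO[C@@H](c3ccc(OC)c(OC)c3)[C@H](C/C=C/c3ccc(OC)c(OC)c3)C2)cc1` gives 32200 nM in the same assay, and compound 3 `Oc1cccc(/C=C/C[C@H]2C[C@@H]([C@@H](O)c3ccccc3)CO[C@@H]2c2ccccc2)c1` gives 18600 nM. Going by the values given here, compound 3 thus has the lowest of the three numbers, but its distance to compound 1 and to compound 2 lies within the scatter, so no order among the three can be read from these values, and no single-change step between measured compounds is available.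

Compound 4 `O[C@@H](c1ccccc1)[C@H]1CO[C@H](c2ccccc2)[C@@H](C/C=C/c2cccnc2)C1` differs from compound 3 in one place: pyridin-3-yl in place of 3-hydroxyphenyl on a double-bonded chain carbon bound to a double-bonded chain carbon. The remainder of the molecule, the shared core with its phenyl groups and hydroxyl, is unchanged. Among the compounds with values here, with no measured step of this kind to lean on, and all three values of the series lying close together, the step is expected to be small and of uncertain direction, with a slight weakening considered somewhat more likely than a strengthening; the expected step is a 1.3-fold higher number from compound 3 to compound 4 (0.13 log units; within the scatter). Compound 4 is therefore estimated at 25000 nM, within a range from 8000 nM to 75000 nM.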

Compound 4, half-maximal inhibitory concentration: > 100000 nM
Compound 4: no number, only a limit; the forecaster's own chance of this, stated with the estimate: 15%; middle value at least 4.0-fold (0.60 log units) from the limit.
By their numbers in this assay, from the lowest: compounds 3, 1 and 2 (each within the scatter of the next). At a limit, above all of these: compound 4.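

In this assay, going by these compounds alone, the end of the chain proves sensitive to a change, which the earlier compounds could not show, as their values lay within the scatter of one another and no single-change step joined them. Pyridin-3-yl in place of 3-hydroxyphenyl on a double-bonded chain carbon bound to a double-bonded chain carbon gives an at least 5.3-fold higher number from compound 3 to compound 4 (0.73 log units; beyond the scatter), so this one change weakens the compound beyond the scatter. Compound 4 is known only through a limit of the assay, not a number, and the step is therefore a lower bound: the limit of > 100000 nM in this assay, at which 1 of the 4 values shown sits.

The compounds shown do not separate the removal of the hydroxyl from the entry of the ring nitrogen, and a plain phenyl, a methoxy group or an amine at this place would bear on that. Going by these compounds, whether pyridin-3-yl has the same effect on the core of compound 1 also stays open.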